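A few compounds are considered here, and "the series" means these few. Any claim that something is new, unique, unknown or untested is made for them only; others in the source may bear on it.

In an ADME assay (liver) for metabolic stability, with Liver microsome (Homo sapiens) as the target, read by LC-MS, using microsomes and NADPH, with a stated time of 5 min, at 37 degrees C (on this read-out lower numbers stand for slow clearance and higher numbers for fast clearance), compound 1 `CCn1c([C@@H](C)NS(=O)(=O)c2c(F)cc(F)cc2F)nc2ccc(C(F)(F)F)cc21` gives 19 mL.min-1.g-1. Compound 2 `CCCn1cc(S(=O)(=O)N[C@H](C)c2nc3ccc(C(F)(F)F)cc3n2CC)c(C)n1` is reported only as a limit, > 100 mL.min-1.g-1. Compound 3 `CCCn1ncc(S(=O)(=O)N[C@H](C)c2nc3ccc(C(F)(F)F)cc3n2CC)c1C` is likewise reported only as a limit, > 100 mL.min-1.g-1. Compound 3 therefore has no number of its own and stands at the limit of > 100 mL.min-1.g-1 in this assay, at which 2 of the 3 values shown sit.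

Compound 4 `CCn1c([C@@H](C)NS(=O)(=O)c2cnc(NC(C)=O)s2)nc2ccc(C(F)(F)F)cc21` keeps the shared core and differs from compound 3 only on the sulfonyl sulfur: 2-acetamido-1,3-thiazol-5-yl in place of 5-methyl-1-propyl-1H-pyrazol-4-yl on a sulfonyl sulfur.

Two measured steps at that same place bear on this change: an at least 5.2-fold higher number from compound 1 to compound 2 (0.72 log units; beyond the scatter) and an at least 5.2-fold higher number from compound 1 to compound 3 (0.72 log units; beyond the scatter). The third, a step that the two limits leave unreadable from compound 2 to compound 3, gives no size. Within the data shown here, the group on the sulfonyl sulfur can thus move the number by a step beyond the scatter, but no measured compound carries the 2-acetamido-1,3-thiazol-5-yl group. With compound 3 at a limit, a modest move toward lower numbers is expected, with wide uncertainty.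

The expected move is an at least 2.8-fold lower number from compound 3 to compound 4 (0.45 log units; beyond the scatter). In this assay, the estimate for compound 4 is 35 mL.min-1.g-1, with an expected range of 12 mL.min-1.g-1 to 100 mL.min-1.g-1.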

Compound 4, intrinsic clearance in microsomes: 15 mL.min-1.g-1
Compound 4: middle estimate off by 2.3-fold (0.37 log units), on the high side; measured number inside the range.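

In this assay, 2-acetamido-1,3-thiazol-5-yl on the sulfonyl sulfur gives an at least 6.6-fold lower number from compound 3 to compound 4 (0.82 log units; beyond the scatter) and an at least 6.6-fold lower number from compound 2 to compound 4 (0.82 log units; beyond the scatter), so a five-membered aromatic ring at this place does not by itself go with the high reading. Set against 2,4,6-trifluorophenyl, the same group gives a 1.3-fold lower number from compound 1 to compound 4 (0.10 log units; within the scatter), so this read-out does not tell those two groups apart. Compound 2 and compound 3 are reported as limits and not as numbers, so the two larger steps fix only a smallest size: the limit of > 100 mL.min-1.g-1 in this assay, at which 2 of the 4 values shown sit.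

The compounds shown do not separate the acetamido part from the thiazole ring that bears it; a free amine or a carboxylic acid in its place would do so. Going by these compounds, the role of the propyl chain in 5-methyl-1-propyl-1H-pyrazol-4-yl also stays open, and a methyl chain in its place would test it.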